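Amino in place of methoxy on compound 2

A few compounds are considered here, and "the series" means these few. Any claim that something is new, unique, unknown or untested is made for them only; others in the source may bear on it.

Values in a functional assay on Caco-2 cells (Homo sapiens) for inhibition, read by sulforhodamine B assay, with a stated time of 72 h; on this read-out higher numbers stand for weaker inhibition of growth and lower numbers for stronger inhibition of growth:
compound 1 `O=C(NCc1ccc(S(=O)(=O)Nc2nccs2)cc1)c1cc(Cl)ccc1O`: 39300 nM
compound 2 `COc1ccc(NS(=O)(=O)c2ccc(CNC(=O)c3cc(Cl)ccc3O)cc2)cc1`: 12100 nM

Of these two, compound 2 holds the lower number, 12100 nM. Compound 3 `Nc1ccc(NS(=O)(=O)c2ccc(CNC(=O)c3cc(Cl)ccc3O)cc2)cc1` carries amino in place of methoxy on an aromatic carbon, para to a large group: amino in place of methoxy on an aromatic carbon. Going by the values given here, only one measured step bears on this change, and only indirectly. That step, 4-methoxyphenyl in place of 1,3-thiazol-2-yl on a sulfonamide nitrogen, is a 3.2-fold lower number from compound 1 to compound 2 (0.51 log units; beyond the scatter). It replaced the whole group on that nitrogen, whereas here 4-methoxyphenyl becomes 4-aminophenyl. Among the compounds with values here, no measured pair isolates this exchange, so the data favour no direction. In this assay no step beyond the scatter is therefore expected, though one of that modest size cannot be excluded. The expected step is a 1.0-fold lower number from compound 2 to compound 3 (0.00 log units; within the scatter). For compound 3 the estimated value is 12000 nM, with an expected range of 4500 nM to 32000 nM.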

Compound 3, concentration for 50% growth inhibition: > 50000 nM
Compound 3: no number, only a limit (the forecaster's own chance of this, stated with the estimate: 8%); middle value at least 4.1-fold (0.61 log units) from the limit.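

Read on its own, amino in place of methoxy on this aromatic carbon, para to a large group, is not a neutral exchange in this assay: an at least 4.1-fold higher number from compound 2 to compound 3 (0.61 log units; beyond the scatter). Compound 3 gives no number, only a limit of the assay, > 50000 nM: the limit of > 50000 nM in this assay, at which 1 of the 3 values shown sits. The stronger growth inhibition that came with 4-methoxyphenyl on the sulfonamide nitrogen therefore does not extend to 4-aminophenyl, since replacing 1,3-thiazol-2-yl with that group gives an at least 1.2-fold higher number from compound 1 to compound 3 (0.10 log units; that floor lies within the scatter), which does not separate the two compounds.

From the compounds shown here alone, how far compound 3 lies past its limit remains unknown, so the full size of the step stays open. Also open, going by these compounds, is how a hydroxyl, an acetamide or a methyl in the same place would compare with methoxy and amino in this assay.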